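Phenylsulfanyl in place of the acetyl-methoxyphenoxy head

The source may report more compounds than this note shows. Statements on the series, on what has been measured and on what is new or still open speak of the compounds shown alone.

Measured compounds:
compound 1 `COc1cc(C(C)=O)ccc1OCCCN1CCC(C(c2ccccc2)c2ccccc2)CC1` gives 6.31 nM
compound 2 `COc1cc(OCCCN2CCC(C(c3ccc(F)cc3)c3ccc(F)cc3)CC2)ccc1C(C)=O` gives 3.16 nM

Both values come from a functional assay (aorta) with Oryctolagus cuniculus as the target; a lower number here means tighter binding, a higher number weaker binding. Compound 2 has the lowest of the two numbers, yet its nearest neighbour is compound 1, whose number is higher by an amount that stays within the scatter of repeated measurements, so the two cannot be ranked against each other.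

The next compound, compound 3 `Fc1ccc(C(c2ccc(F)cc2)C2CCN(CCCSc3ccccc3)CC2)cc1`, keeps the diphenylmethylpiperidine part of compound 2 bearing two fluorines and alters only the far end of the chain: phenylsulfanyl in place of 4-acetyl-3-methoxyphenoxy on a saturated chain carbon, three bonds along the chain from an amine nitrogen in a ring. The group that leaves carries the carbonyl and the methoxy, the group that enters is smaller and has a single acceptor.

Among the measured compounds shown here, no measured pair shows a change of this kind, so the size of the step can only be guessed. The author expects compound 3 to give 10 nM in this assay, with a range from 2.5 nM to 40 nM. This estimate amounts to a step of a 3.2-fold higher number from compound 2 to compound 3 (0.50 log units; beyond the scatter), expected to go toward a higher number and to reach somewhat beyond the scatter.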

Compound 3, dissociation constant: 3.16 nM
Compound 3: middle estimate off by 3.2-fold (0.50 log units), on the high side; low and high end bracket the measured number.
By their numbers in this assay, from the lowest: compounds 2, 3 and 1 (each within the scatter of the next).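

In this assay, among the compounds shown here, the exchange of 4-acetyl-3-methoxyphenoxy for phenylsulfanyl gives no change at the digits printed from compound 2 to compound 3 (within the scatter), which is the first step read at this end of the chain. On the core bearing two fluorines, this position therefore accepts a head of fewer heavy atoms in place of 4-acetyl-3-methoxyphenoxy, and the carbonyl and methoxy of compound 2 are not needed to keep the number within the scatter. Nothing available explains this outcome.

The single step swaps the linking atom and removes both ring substituents at once, so the compounds shown leave open what each of these contributes on its own; a plain phenoxy head, or phenylsulfanyl carrying only an acetyl or only a methoxy, would separate them. Also open, as far as these compounds go, is how far this tolerance extends, whether to a phenylsulfanyl ring bearing an amine or a carboxylic acid, to a longer chain, or to the core of compound 1 without its fluorines.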